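The source may report more compounds than this note shows. Statements on the series, on what has been measured and on what is new or still open speak of the compounds shown alone.

Working notes on the series. Within the data shown here, in an ADME assay on the whole organism (Rattus norvegicus) for metabolic stability, using cassette dosing (a higher number here means faster removal of the compound, a lower number slower removal), compound 1 (`CN[C@H](CNc1cc(F)c(S(=O)(=O)Nc2ncc(F)s2)cc1Cl)CC12CC(C1)C2`) gives 2300 mL/min/kg and compound 2 (`CN[C@H](CNc1cc(F)c(S(=O)(=O)Nc2ncc(F)s2)cc1Cl)CC1(C)CC1`) gives 830 mL/min/kg, the lower of the two numbers so far.

Compound 3 (`CN[C@H](CNc1cc(F)c(S(=O)(=O)Nc2ncc(F)s2)cc1Cl)CC1CC1`) is the next to be read. Its difference from compound 2 is hydrogen in place of methyl on a saturated ring carbon. In words, this is hydrogen in place of methyl on a saturated ring carbon, turning 1-methylcyclopropyl into cyclopropyl.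

Among the measured compounds shown here, only one measured step bears on this: a 2.8-fold lower number from compound 1 to compound 2 (0.44 log units; beyond the scatter). It also ended in a smaller group, but it exchanged a whole carbon ring group rather than removing a single methyl, so it is a loose guide. For the measured compounds named here, no measured step isolates this methyl. With two measured compounds, no trend can be claimed.

A small further fall in this assay is the lean, but no change beyond the scatter is expected. The expected move is a 1.3-fold lower number from compound 2 to compound 3 (0.11 log units; within the scatter). For compound 3 the estimated clearance is 650 mL/min/kg, with an expected range of 280 mL/min/kg to 1500 mL/min/kg.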

Compound 3, clearance: 380 mL/min/kg
Compound 3: middle estimate off by 1.7-fold (0.23 log units), on the high side, and the stated range covers the measured number.
By their numbers in this assay, from the lowest: compound 3; then compound 2; then compound 1.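

In this assay, the single methyl on the saturated ring carbon now has a measured effect of its own: turning 1-methylcyclopropyl into cyclopropyl gives a 2.2-fold lower number from compound 2 to compound 3 (0.34 log units; beyond the scatter) and so moves the number beyond the scatter without any change of ring. The three compounds differ only in the group on a saturated chain carbon, two bonds along the chain from an amine nitrogen, and the number falls as that group gets smaller, with none of the three going against this order and with a 6.1-fold lower number from compound 1 to compound 3 (0.78 log units; beyond the scatter) as the widest step. Nothing measured here speaks to why the number falls.

Still open, going by these compounds, is whether the fall continues with a smaller open chain on that carbon, such as ethyl or plain methyl, or whether it depends on the cyclopropyl ring itself, which a comparison with isobutyl or cyclobutyl would separate from group size. Also open, on these data alone, is how a group carrying oxygen or nitrogen at this place, such as a hydroxyl, an ether or an amine, would read in this assay against cyclopropylmethyl.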